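Clearance notes: methoxy for chloro on the shared core

The source may report more compounds than this note shows. Statements on the series, on what has been measured and on what is new or still open speak of the compounds shown alone.

Measured so far:
compound 1, `O=C(O)c1csc(-n2nc(-c3cccc(F)c3)c3ccccc32)n1`, 385 mL/min/kg
compound 2, `O=C(O)c1csc(-n2nc(-c3ccc(Cl)cc3)c3ccccc32)n1`, 753 mL/min/kg

In an ADME assay (liver) for metabolic stability, with Liver microsome (Rattus norvegicus) as the target, using microsomes (on this read-out higher numbers stand for fast clearance and lower numbers for slow clearance), compound 2 gives 753 mL/min/kg, the highest of the two numbers seen; its nearest neighbour is compound 1 at 385 mL/min/kg, and the step of a 2.0-fold higher number from compound 1 to compound 2 (0.29 log units; within the scatter) lies within the scatter, so no order between the two can be read.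

Compound 3, `COc1ccc(-c2nn(-c3nc(C(=O)O)cs3)c3ccccc23)cc1`, is not yet measured. Against compound 2 it shows (methoxy in place of chloro on an aromatic carbon), sitting on an aromatic carbon of a six-membered aromatic ring of carbon only, para to a large group; cut one bond further out, the change reads 4-chlorophenyl to 4-methoxyphenyl.

Within the data shown here, only one measured step touches this ring, a 2.0-fold higher number from compound 1 to compound 2 (0.29 log units; within the scatter), and it stayed within the scatter. A change of substituent on this ring has therefore not yet moved the read-out beyond its noise, and nothing else in the data bears on a methoxy here. The expectation for this assay is accordingly a step of about a 1.2-fold lower number from compound 2 to compound 3 (0.06 log units; within the scatter), that is, none beyond the scatter. Compound 3 is estimated at 650 mL/min/kg, with a range from 300 mL/min/kg to 1400 mL/min/kg.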

Compound 3, clearance: 618 mL/min/kg
The estimate for compound 3 lay 1.1-fold (0.02 log units) above the measured number; low and high end bracket the measured number.
By their numbers in this assay, from the lowest: compounds 1, 3 and 2 (each within the scatter of the next).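

In this assay the exchange of chloro for methoxy on an aromatic carbon, para to a large group, gives a 1.2-fold lower number from compound 2 to compound 3 (0.09 log units; within the scatter) and stays within the scatter, so this position has now taken a group with a hydrogen-bond acceptor in place of one without, and no shift can be read. The wider change, 4-methoxyphenyl in place of 3-fluorophenyl, gives a 1.6-fold higher number from compound 1 to compound 3 (0.21 log units; within the scatter) and also stays within the scatter, which leaves compound 1, compound 2 and compound 3 without any order on this read-out, since all of their steps lie inside the noise. Nothing measured alongside these clearance numbers speaks to what lies behind them.

The compounds shown carry only fluoro, chloro and methoxy on this ring, so it remains open whether an amine, a nitrile or a longer alkoxy chain on the same carbon would move the clearance beyond the scatter. From the compounds shown here alone, the carboxylic acid stays the same throughout the shared core, so the effect of an amide or an ester in its place also remains open.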